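An isopropyl step repeated across two cores

The source may report more compounds than this note shows. Statements on the series, on what has been measured and on what is new or still open speak of the compounds shown alone.

Compound 1 `C[C@H](NCCC1OCC(C)(C)CO1)C(=O)N[C@H]1[C@@H](OCc2ccccc2)O[C@H](COCc2ccccc2)[C@@H](OCc2ccccc2)[C@@H]1OCc1ccccc1` and compound 2 `CC(C)C[C@H](NCCC1OCC(C)(C)CO1)C(=O)N[C@H]1[C@@H](OCc2ccccc2)O[C@H](COCc2ccccc2)[C@@H](OCc2ccccc2)[C@@H]1OCc1ccccc1` share one core, while compound 3 `C[C@H](NCCC1OCC(C)(C)CO1)C(=O)N[C@H]1C(O)O[C@H](CO)[C@@H](O)[C@@H]1O` and compound 4 `CC(C)C[C@H](NCCC1OCC(C)(C)CO1)C(=O)N[C@H]1C(O)O[C@H](CO)[C@@H](O)[C@@H]1O` share another; how the two cores differ is not broken down here. In a functional assay on the whole organism (Ear, strain ICR) for inhibition, with Mus musculus as the target, with stated times of 30 min and 2 h, at a dose of 10 umol/kg by the oral route (a higher number here means more inhibition at the dose given (going by the name of the read-out), a lower number less inhibition), compound 1 gives 90.3%. Compound 2 differs from compound 1 by isopropyl in place of hydrogen on a saturated chain carbon, two bonds along the chain from an amine nitrogen and a carbonyl carbon, and that change made the step of a number 13.6 percentage points lower from compound 1 to compound 2 (beyond the scatter). In this assay compound 3 gives 86.8%, which lies within the scatter of the reading for compound 1, so the two cannot be ordered, and compound 2 gives 76.7%.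

Compound 4 differs from compound 3 by isopropyl in place of hydrogen on a saturated chain carbon, two bonds along the chain from an amine nitrogen and a carbonyl carbon, the same change as between compound 1 and compound 2, at a place described in the same words. The expectation for compound 4 rests on that single earlier instance: because the step of a number 13.6 percentage points lower from compound 1 to compound 2 (beyond the scatter) was a modest loss beyond the scatter, a loss of about the same size is expected here, as a number 13.8 percentage points lower from compound 3 to compound 4 (beyond the scatter). Among the measured compounds shown here, only one prior example of the change exists, so the range around the estimate is kept wide. Compound 4 is expected to give 73% in this assay, with a likely range from 58% to 86%.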

Compound 4, a percentage reported as inhibition, in the whole organism at one dose (the size of the read-out at that dose, not a potency): 81.8%
Beside the measured number, compound 4's estimate is 8.8 percentage points below it; low and high end bracket the measured number.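

In this assay, the isopropyl change on the core of compound 3 gives a number 5 percentage points lower from compound 3 to compound 4 (within the scatter), and set beside the same change on the core of compound 1, the two steps cannot be told apart: the same change on two cores in this assay, a number 13.6 percentage points lower (beyond the scatter) from compound 1 to compound 2 and a number 5 percentage points lower (within the scatter) from compound 3 to compound 4, 8.6 percentage points apart, within the scatter of two such steps. This shows that, in these two pairs, the effect of the change on the core of compound 1 and its effect on the core of compound 3 are compatible with a single step size, so the first pair gave no misleading guide to the second. Among the compounds shown here, it does not show that the two steps are equal or that the change lowers the read-out on both cores, as only the step on the core of compound 1 lies beyond the scatter, and two pairs tested at one dose cannot settle whether the core alters the size of the step.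

The compounds shown leave open how other groups on the same saturated chain carbon would read, such as a longer straight chain, a phenyl ring, an amine or a carboxylic acid. They also leave open whether the step from hydrogen to isopropyl would hold on any third core.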